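Nitro for propoxy: tolerance notes on compound 3

The source may hold more compounds than are shown below. What is called first, only, known or untested is meant among the compounds shown, and "the series" means these compounds.

- compound 1 `NC(=O)c1c(NC(=O)c2nc3nccc(-c4ccccc4)n3n2)sc2c1CCCCC2` reads > 200000 nM as a limit
- compound 2 `CCCOc1ccc(C(=O)Nc2nc3nc(-c4ccccc4)cc(C)n3n2)cc1` reads 247000 nM as a number

Among the compounds with values here, compound 2 reads 247000 nM in an ADME assay on MDCK cells (Canis lupus familiaris) for cytotoxicity, read by MTT assay, with a stated time of 48 h (a lower number here means that less compound is tolerated, a higher number that more compound is tolerated), and holds the only true number of the series so far. Compound 1 gives > 200000 nM and that is a limit, not a number.

The step to compound 3 `Cc1cc(-c2ccccc2)nc2nc(NC(=O)c3ccc([N+](=O)[O-])cc3)nn12` puts nitro in place of propoxy on an aromatic carbon para to a large group. Within the data shown here, no measured pair shows a single change, so the judgement starts from compound 2 at 247000 nM alone. In this assay no step beyond the scatter is expected, with any drift leaning toward less compound tolerated, and the reading may well end as a limit. The estimated change is a 1.4-fold lower number from compound 2 to compound 3 (0.14 log units; within the scatter) and it is expected to stay small. For compound 3 the expected value is 180000 nM within a range of 70000 nM to 350000 nM as a working estimate.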

Compound 3, half-maximal cytotoxic concentration: > 250000 nM
Compound 3: only a limit was reported; the forecaster's own chance of this, stated with the estimate: 45%; middle value at least 1.3-fold (0.14 log units) from the limit.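

Nitro in place of propoxy on an aromatic carbon, para to a large group, gives an at least 1.0-fold higher number from compound 2 to compound 3 (0.00 log units; that floor lies within the scatter). In this assay compound 3 gives > 250000 nM, which is a limit and not a number. Within the data shown here, this is the first single change that can be read, and it shows that this position takes nitro with no loss of tolerance in the cells, although the true size of the step stays unknown.

As far as these compounds go, whether an amine or a carboxylic acid at this position, or a longer chain in place of propoxy, would leave the reading as high remains open. Only a true number for compound 3 could show how far nitro and propoxy actually differ at this position.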